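The source may hold more compounds than are shown below. What is called first, only, known or untested is meant among the compounds shown, and "the series" means these compounds.

Compound 1 `C/C=C/C(=O)N(Cc1ccc(OC)c([N+](=O)[O-])c1)c1cc(OC)c(OC)c(OC)c1`: 590 nM
Compound 2 `COc1cc(NCc2ccccc2)cc(OC)c1OC`: > 80000 nM (a limit, not a number)

Going by the values given here, in a functional assay on MGC-803 cells (Homo sapiens) for inhibition, read by MTT assay, with a stated time of 48 h (on this read-out higher numbers stand for weaker inhibition and lower numbers for stronger inhibition), compound 1 gives 590 nM, the only actual number so far. Compound 2 gives > 80000 nM, which is a limit of the assay. Compound 1 therefore stands clear on the stronger side of that limit, but no exact gap between the two can be stated.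

The next compound is compound 3 `COc1ccc(CNc2cc(OC)c(OC)c(OC)c2)cc1[N+](=O)[O-]`. It is compound 1 with one change: hydrogen in place of (prop-1-en-1-yl)carbonyl on a nitrogen on an aromatic ring. In words, hydrogen stands in place of (prop-1-en-1-yl)carbonyl on a nitrogen on an aromatic ring. Among the compounds with values here, no pair of measured compounds shows this change alone, so any forecast is uncertain. Compound 2 also carries a hydrogen on a nitrogen on an aromatic ring, and its reading is the limit > 80000 nM. On that single precedent, a large step towards weaker inhibition in this assay is expected, well beyond the usual scatter. The expected change is a 25-fold higher number from compound 1 to compound 3 (1.41 log units; beyond the scatter). For compound 3 the estimated value is 15000 nM, with an expected range from 2500 nM to 80000 nM.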

Compound 3, half-maximal inhibitory concentration: 19400 nM
For compound 3 the middle estimate is 1.3-fold (0.11 log units) below the measured one; the measured number falls inside the stated range.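

In this assay, going by these compounds alone, replacing the (prop-1-en-1-yl)carbonyl on the nitrogen with a plain hydrogen gives a 33-fold higher number from compound 1 to compound 3 (1.52 log units; beyond the scatter), and this is the first change whose size can be read as a real number at both ends. It shows that this nitrogen is not a neutral spot: the group attached there makes a large difference to how strongly the compound inhibits these cells, yet compound 3 without that group still gives a measurable value of 19400 nM. Compound 2 is the only one of the three that stays at a limit, which is not a number, while this step needs no limit to be read: the limit of > 80000 nM in this assay, at which 1 of the 3 values shown sits.

The compounds shown compare only two options at this nitrogen, the whole (prop-1-en-1-yl)carbonyl group and hydrogen, so they cannot tell which part of that group matters. A small acetyl group would show what the carbonyl can do on its own, and a saturated butanoyl group would show whether the double bond in the chain makes any difference.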